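Removing the drawn configurations of compound 3

The source may hold more compounds than are shown below. What is called first, only, known or untested is meant among the compounds shown, and "the series" means these compounds.

The set consists of three measured dihydropyridine esters bearing nitrate-carrying side chains. Compound 1 `CC1=C(C(=O)OCCCCO[N+](=O)[O-])C(c2cccc3nonc23)C([N+](=O)[O-])=C(C)C1` gives 4030 nM in a functional assay (cardiac atrium) for agonist activity, with Cavia porcellus as the target (on this read-out lower numbers stand for an effect already at smaller amounts and higher numbers for an effect only at larger amounts of compound), and compound 2 `CC1=C(C(=O)OCCO[N+](=O)[O-])[C@H](c2cccc3nonc23)C([N+](=O)[O-])=C(C)C1` gives 3130 nM. Compound 3 `CC1=C(C(=O)O[C@@H](C)CO[N+](=O)[O-])[C@@H](c2cccc3nonc23)C([N+](=O)[O-])=C(C)C1`, drawn as a single stereoisomer with both centres defined, gives 33700 nM, the highest number of the three, and its gap to both compound 1 and compound 2 lies beyond the usual scatter.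

Compound 4 `CC1=C(C(=O)OC(C)CO[N+](=O)[O-])C(c2cccc3nonc23)C([N+](=O)[O-])=C(C)C1` has the same atoms and bonds as compound 3; the difference is the two compounds have the same atoms and bonds; at least one stereo element is drawn with a configuration in one of them and without one in the other: 2 of 2 stereo elements differ; a stereocentre at a saturated chain carbon is drawn S in compound 3 and without a configuration in compound 4; a stereocentre at a saturated ring carbon is drawn R in compound 3 and without a configuration in compound 4. Compound 4 therefore stands for the material with both centres left undefined, which may contain the isomer of compound 3 together with the others. For the measured compounds named here, no step between measured compounds helps here. Since compound 3 gives 33700 nM, the highest value, a mixture containing other isomers is expected to give a somewhat lower number, so the expected step from compound 3 to compound 4 is a 2.8-fold lower number from compound 3 to compound 4 (0.45 log units; beyond the scatter), a moderate drop. Compound 4 is estimated at 12000 nM, with a range from 4000 nM to 40000 nM.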

Compound 4, half-maximal effective concentration: 1860 nM
The estimate for compound 4 lay 6.5-fold (0.81 log units) above the measured number; measured number below the stated range.
By their numbers in this assay, from the lowest: compounds 4, 2 and 1 (each within the scatter of the next, the first and the last beyond it); then compound 3.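

In this assay, for the compounds shown here, the drawn configurations at the two stereocentres prove to matter far more than the earlier compounds suggested, with an 18-fold lower number from compound 3 to compound 4 (1.26 log units; beyond the scatter) at an unchanged set of atoms and bonds. The high number of compound 3 therefore does not belong to its branched side chain as such, since the undefined material with the same chain gives the lowest number of the set, and a 2.2-fold lower number from compound 1 to compound 4 (0.34 log units; beyond the scatter) accompanies the group of 7 heavy atoms in place of the group of 8 heavy atoms. The large step rests on a single difference: the fact that one of compounds 3 and 4 is drawn with a defined configuration and the other without, at the place where they differ.

The compounds shown leave open which of the two centres, the chain carbon or the ring carbon, carries the step, and which isomer within compound 4 gives its number. On these data alone, how an amine in place of the nitrate would read also stays open.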